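Replacing sulfo with 2H-tetrazol-5-yl in compound 3

The compounds below may be only part of what the source reports. "The series", "measured", "known", "first", "only" and "open" are said of these compounds alone.

In a physicochemical assay for lipophilicity, using the shake flask method (a higher number here means a more lipophilic compound, a lower number a more polar compound), compound 3 (`C[C@H](Oc1ccc2ncc(/C=C/S(=O)(=O)O)c(C3CC3)c2c1)c1c(Cl)ccc(F)c1Cl`) gives 2.5 and stands in the middle of the three numbers, with compound 1 (`C[C@H](Oc1ccc2ncc(CCC(=O)O)c(C3CC3)c2c1)c1c(Cl)ccc(F)c1Cl`) higher at 4.1 and compound 2 (`C[C@H](Oc1ccc(NC(=O)CC(=O)O)c(C2CC2)c1)c1c(Cl)ccc(F)c1Cl`) lower at 1.9 on the same scale. In compound 4 (`C[C@H](Oc1ccc2ncc(/C=C/c3nn[nH]n3)c(C3CC3)c2c1)c1c(Cl)ccc(F)c1Cl`) 2H-tetrazol-5-yl stands in place of sulfo on a double-bonded chain carbon bound to a double-bonded chain carbon (2H-tetrazol-5-yl in place of sulfo on a double-bonded chain carbon bound to a double-bonded chain carbon). Within the data shown here, one measured step bears on this, and it is large (a number 1.60 log units lower from compound 1 to compound 3 (beyond the scatter)), though no measured step starts from sulfo. A step upward in this assay is therefore expected, beyond the scatter but smaller than that one. The expected step is moderate (a number 0.80 log units higher from compound 3 to compound 4 (beyond the scatter)). The estimate for compound 4 is 3.3 with 2.7 to 3.9 as its expected range.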

Compound 4, distribution coefficient: 3.7
For compound 4 the middle estimate is 0.40 log units below the measured one; the range from low to high includes it.
By their numbers in this assay, from the lowest: compound 2; then compound 3; then compound 4; then compound 1.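

At this double-bonded chain carbon, 2H-tetrazol-5-yl in place of sulfo moves the number substantially in this assay (a number 1.20 log units higher from compound 3 to compound 4 (beyond the scatter)), so the measured value depends strongly on which of these two groups is present. Set against 2-carboxyethyl on the aromatic carbon, 2-(2H-tetrazol-5-yl)ethenyl gives a smaller step (a number 0.40 log units lower from compound 1 to compound 4 (beyond the scatter)) than the sulfo-bearing chain does (a number 1.60 log units lower from compound 1 to compound 3 (beyond the scatter)). No accompanying data explain either step.

Going by these compounds, whether a sulfonamide or an amine at this chain carbon would fall near compound 3 or compound 4 remains open. The separate contributions of the double bond and the tetrazole also remain unresolved, since compound 4 differs from compound 1 in both.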